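Amide nitrogen substituent removal on two mirror-image cores

This account rests on a few compounds, and the source may have more. Where it says the series, first, only, none or still open, it means among the compounds named here.

The study compares four compounds that share one carbocyclic core bearing a phenyl group and an amide, examined in an assay on isolated protein for inhibition of Apoptosis regulator Bcl-2 (Homo sapiens), read by fluorescence polarization, with stated times of 5 min and 10 min; a lower number here means a stronger inhibitor, a higher number a weaker inhibitor. Compound 1 `CC(C)=CCCC1=CC[C@H](C(=O)Nc2ccc(O)cc2)[C@@H](c2ccccc2)C1` carries a 4-hydroxyphenyl on the amide nitrogen; in this assay compound 1 gives only a limit, > 23000 nM. Compound 2 `CC(C)=CCCC1=CC[C@H](C(N)=O)[C@@H](c2ccccc2)C1` differs from compound 1 by hydrogen in place of 4-hydroxyphenyl on an amide-type nitrogen. In this assay compound 2 likewise gives only a limit, > 23000 nM. The step that the two limits leave unreadable from compound 1 to compound 2 therefore cannot be sized, because of the limit of > 23000 nM in this assay, at which 3 of the 3 values shown sit.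

Compound 3 `CC(C)=CCCC1=CC[C@@H](C(=O)Nc2ccc(O)cc2)[C@H](c2ccccc2)C1` is the mirror image of compound 1: the two compounds have the same atoms and bonds and differ only in configuration as drawn: 2 of 2 stereo elements differ (all stereocentres are inverted: mirror images); a stereocentre at a saturated ring carbon is drawn S in compound 1 and R in compound 3; a stereocentre at a saturated ring carbon is drawn S in compound 1 and R in compound 3. In this assay compound 3 also gives only a limit, > 23000 nM. The step that the two limits leave unreadable from compound 1 to compound 3 is equally unreadable, because of the limit of > 23000 nM in this assay, at which 3 of the 3 values shown sit, even though the fact that compounds 1 and 3 differ only in the configuration as drawn would otherwise make it a clean comparison of configuration alone.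

Compound 4 `CC(C)=CCCC1=CC[C@@H](C(N)=O)[C@H](c2ccccc2)C1` has not yet been measured. It stands to compound 3 as compound 2 stands to compound 1: hydrogen in place of 4-hydroxyphenyl on an amide-type nitrogen, the same change at the same place, here made on the mirror-image core. Within the data shown here, since the one prior instance of this change, from compound 1 to compound 2, produced no readable step and all three measured values sit at the same limit, the expected step from compound 3 to compound 4 is estimated as a step that the limit leaves unreadable from compound 3 to compound 4, essentially none. Compound 4 is accordingly expected to give 40000 nM in this assay, with a range estimated from 15000 nM to 150000 nM, most probably reported as a limit again.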

Compound 4, inhibition constant: > 23000 nM
Compound 4 was reported as a limit; the forecaster's own chance of this, stated with the estimate: 85%; the middle value lies beyond the limit too.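

Compound 4 gives only a limit in this assay, so neither the step to it from compound 3 nor the step to it from compound 2 can be read, because of this: the limit of > 23000 nM in this assay, at which 4 of the 4 values shown sit.

The compounds shown leave open whether hydrogen in place of 4-hydroxyphenyl, or the inversion of configuration, changes inhibition at all in this assay.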